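The compounds below may be only part of what the source reports. "The series", "measured", "known", "first", "only" and "open" are said of these compounds alone.

Working notes on the series. In a functional assay on the whole organism (strain BALB/c) with Mus musculus as the target, with a stated time of 4 h (a higher number here means that more compound is needed for the effect, a lower number that less compound is needed), compound 1 `CC1=C(CN2CC(C(=O)O)C2)CCc2cc(OCC3CCc4ccccc4C3)ccc21` stands at "not determined" (no result reported), so it offers no number to start from. Compound 2 `CC1=C(CN2CC(C(=O)O)C2)CCc2cc(OCCC3CCCc4ccccc43)ccc21` is in the same position at "not determined" (no result reported). Compound 3 `CC1=C(CN2CC(C(=O)O)C2)CCc2cc(OCc3ccc(CC(C)C)cc3F)ccc21` gives 0.073 mg/kg, the only numerical result so far, and it is therefore the sole anchor for this series.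

Compound 4 `COc1cc(C)ccc1COc1ccc2c(c1)CCC(CN1CC(C(=O)O)C1)=C2C` keeps the shared core of compound 1 and changes only the group on a saturated chain carbon bound to an oxygen on an aromatic ring: 2-methoxy-4-methylphenyl in place of 1,2,3,4-tetrahydronaphthalen-2-yl on a saturated chain carbon bound to an oxygen on an aromatic ring. The size of the step from compound 1 cannot be read from the data, as compound 1 has no value to compare. Measured against compound 3 at 0.073 mg/kg, a moderate step towards a higher dose in this assay is expected, somewhat beyond the usual scatter, though this rests on a single data point and the range is kept wide. For compound 4 the estimated dose is 0.3 mg/kg, with an expected range of 0.06 mg/kg to 1.5 mg/kg.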

Compound 4, dose for half-maximal effect: > 0.1 mg/kg
Compound 4: a limit, no number; the forecaster's own chance of this, stated with the estimate: 10%; the middle value lies beyond the limit too.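

In this assay compound 4 gives > 0.1 mg/kg, which is a limit and not a number. No step can be read between compound 1, which offers no number, and compound 4. The compounds shown leave open how the dose changes when 2-methoxy-4-methylphenyl replaces 1,2,3,4-tetrahydronaphthalen-2-yl.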